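A few compounds are considered here, and "the series" means these few. Any claim that something is new, unique, unknown or untested is made for them only; others in the source may bear on it.

Working notes on the series.

Compound 1 `CC1=CC[C@H](C(C)C)c2cc(C)c(OC(=O)c3ccc(C)cc3)cc21` gives 78.9% in a functional assay on HCT-15 cells (Homo sapiens) for antiproliferative activity, read by sulforhodamine B assay, with a stated time of 48 h, tested at 50 uM; on this read-out higher numbers stand for more inhibition at the one concentration tested (going by the name of the read-out) and lower numbers for less inhibition. Among the three measured compounds it stands second highest: compound 3 `Cc1cc2c(C(C)C)ccc(C)c2cc1OC(=O)c1ccc([N+](=O)[O-])cc1`, which gives 97.6%, lies above it by a margin beyond the scatter, and compound 2 `COc1cccc(C(=O)Oc2cc3c(C)ccc(C(C)C)c3cc2C)c1`, which gives 35.2%, lies well below it, also beyond the scatter. Compounds 2 and 3 carry a core different from that of compound 1, so their numbers frame the range seen so far rather than the core of compound 1 itself.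

Compound 4 `CC1=CC[C@H](C(C)C)c2cc(C)c(OC(=O)c3cccc(C)c3)cc21` differs from compound 1 in one place: 3-methylphenyl in place of 4-methylphenyl on a carbonyl carbon.

Among the measured compounds shown here, the only single-point step measured, a number 62.4 percentage points higher from compound 2 to compound 3 (beyond the scatter), swaps two quite different groups at the same carbonyl carbon and sits on the other core; it shows that the aryl group on the ester can move the read-out strongly, but neither of the groups it compares is a methylphenyl, so it does not speak directly to the move of a methyl around the ring. For the measured compounds named here, no measured pair isolates this change. The expectation is therefore a step of a number 8.9 percentage points lower from compound 1 to compound 4 (within the scatter), close to no change beyond the scatter, with wide uncertainty. Compound 4 is estimated at 70%, within 45% to 90%.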

Compound 4, a percentage reported as inhibition, at one concentration (the size of the read-out at that concentration, not a potency): 5.3%
Compound 4: middle estimate off by 64.7 percentage points, on the high side; measured number below the stated range.
By their numbers in this assay, from the lowest: compound 4; then compound 2; then compound 1; then compound 3.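

The aryl group on this carbonyl carbon proves sensitive in this assay to where a single methyl sits on the ring, with a step of a number 73.6 percentage points lower from compound 1 to compound 4 (beyond the scatter), although 4-methylphenyl and 3-methylphenyl match in everything counted for them and differ only in how the same atoms are joined. The earlier step of a number 62.4 percentage points higher from compound 2 to compound 3 (beyond the scatter) exchanged two quite different groups on the other core, so it could not show that a change this small, made on the core of compound 1, can also move the read-out this far. No measurement at hand bears on what lies behind this step.

The compounds shown leave open whether moving the methyl has a comparable effect on the core of compounds 2 and 3, since no methylphenyl ester on that core appears here. They also leave open how the read-out responds on the core of compound 1 when the methyl on the ring gives way to a longer chain such as ethyl, or to an amine.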